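The source may hold more compounds than are shown below. What is called first, only, known or untested is meant among the compounds shown, and "the series" means these compounds.

Measured so far in the series:

compound 1, `Cc1ccc(S(=O)(=O)N2C(=O)NCC2c2ccc(Br)cc2)cc1`: 67000 nM
compound 2, `O=C1NCC(c2ccc(Br)cc2)N1S(=O)(=O)c1ccc(Cl)cc1`: 84000 nM
compound 3, `Cc1ccc(S(=O)(=O)N2CC(c3ccccc3)NC2=O)cc1`: 12500 nM

In a functional assay on A549 cells (Homo sapiens) for cytotoxicity (a higher number here means a weaker inhibitor, a lower number a stronger inhibitor), compound 3 gives 12500 nM, the lowest of the three numbers, and its gaps to compound 1 and compound 2 are both beyond the usual scatter. How the core of compound 3 differs from the core of compound 1 is not broken down here; the two values alone show compound 3 with the lower number.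

Compound 1 and compound 2 differ in one place: chloro in place of methyl on an aromatic carbon That change gave a 1.3-fold higher number from compound 1 to compound 2 (0.10 log units; within the scatter)

Compound 4, `O=C1NC(c2ccccc2)CN1S(=O)(=O)c1ccc(Cl)cc1`, stands to compound 3 exactly as compound 2 stands to compound 1: chloro in place of methyl on an aromatic carbon The surroundings of the change read the same word for word in both pairs, so it is the same change made on the other core. Within the data shown here, only this one precedent for it is available, and it comes from the weaker core, so the transfer to the core of compound 3 is an assumption rather than a tested pattern.

The expected step is a 1.2-fold higher number from compound 3 to compound 4 (0.08 log units; within the scatter), resting on the same change having given a 1.3-fold higher number from compound 1 to compound 2 (0.10 log units; within the scatter) and on nothing beyond that single precedent. Compound 4 is therefore expected to give 15000 nM in this assay, with a plausible range from 6000 nM to 40000 nM, the range kept wide since the step is carried over from a different core.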

Compound 4, half-maximal inhibitory concentration: 9470 nM
Compound 4: the middle estimate sits 1.6-fold (0.20 log units) above what was measured; the measured number falls inside the stated range.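

In this assay, chloro in place of methyl on an aromatic carbon gives a 1.3-fold lower number from compound 3 to compound 4 (0.12 log units; within the scatter), so 4-methylphenyl and 4-chlorophenyl cannot be told apart on the core of compound 3. Among these compounds, the step agrees with its one precedent on the other core, and the opposite directions printed for the two steps carry no weight: the same change on two cores in this assay, a 1.3-fold higher number (0.10 log units; within the scatter) from compound 1 to compound 2 and a 1.3-fold lower number (0.12 log units; within the scatter) from compound 3 to compound 4, 1.7-fold (0.22 log units) apart, within the scatter of two such steps This shows that the swap carried over between these two cores as a step too small to read in this cytotoxicity measurement; it does not show a general rule for the series, since it rests on two pairs and one change, and it says nothing about why the swap makes so little difference.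

The compounds shown leave open whether a group of another kind on that aromatic carbon, such as an amine, a carboxylic acid or a longer chain, would give a step beyond the scatter on either core. Also open, on these data alone, is which feature separating the core of compound 1 from the core of compound 3 goes with the difference in their values.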